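Nitro to methyl: a step expected to stay flat

A few compounds are considered here, and "the series" means these few. Any claim that something is new, unique, unknown or untested is made for them only; others in the source may bear on it.

Measured so far in a functional assay on A549 cells (Homo sapiens) for inhibition, read by MTT assay, with a stated time of 72 h; on this read-out lower numbers stand for stronger inhibition and higher numbers for weaker inhibition:
compound 1 `COc1ccc(-c2nnc(SCCCN3CCN(c4nc5ccccc5s4)CC3)o2)cc1`: 90300 nM
compound 2 `O=[N+]([O-])c1ccc(-c2nnc(SCCCN3CCN(c4nc5ccccc5s4)CC3)o2)cc1`: 96600 nM

Compound 2, at 96600 nM, lies within the scatter of compound 1. Compound 3 `Cc1ccc(-c2nnc(SCCCN3CCN(c4nc5ccccc5s4)CC3)o2)cc1` has not yet been measured and differs from compound 2 by one change: methyl in place of nitro on an aromatic carbon. Going by the values given here, the one measured step that bears on this also exchanges the nitro group, a 1.1-fold higher number from compound 1 to compound 2 (0.03 log units; within the scatter), and it is within the scatter. No step beyond the scatter is therefore expected in this assay. The estimated step is a 1.1-fold lower number from compound 2 to compound 3 (0.06 log units; within the scatter) and would stay inside the scatter. Compound 3 is expected at 85000 nM, with an estimated range of 40000 nM to 150000 nM for its value.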

Compound 3, half-maximal inhibitory concentration: 53900 nM
Beside the measured number, compound 3's estimate is 1.6-fold (0.20 log units) above it, within the range that was stated.
By their numbers in this assay, from the lowest: compounds 3, 1 and 2 (each within the scatter of the next).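

In this assay, methyl on an aromatic carbon para to a large group gives a 1.8-fold lower number from compound 2 to compound 3 (0.25 log units; within the scatter) and a 1.7-fold lower number from compound 1 to compound 3 (0.22 log units; within the scatter). Nitro, methoxy and methyl, which share no atoms beyond the attached carbon or heteroatom pattern of their own, therefore all lie within the scatter of one another at this place, whereas the earlier pair had shown this only for nitro and methoxy. No measurement at hand offers a reason for these numbers. The compounds shown leave open whether an amine or a carboxylic acid at this place would give a step beyond the scatter.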